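Same atoms, joined differently: compound 3 to compound 4

The source may hold more compounds than are shown below. What is called first, only, known or untested is meant among the compounds shown, and "the series" means these compounds.

In a functional assay on HCT-116 cells (Homo sapiens) for antiproliferative activity, with a stated time of 72 h (on this read-out higher numbers stand for weaker inhibition and lower numbers for stronger inhibition), compound 1 `CN(Cc1ccc(C(=O)Nc2cc(-c3ccccc3)ccc2N)cc1)c1ccncc1` gives 3610 nM and compound 2 `Cc1c(CNc2ccc(C(=O)Nc3cc(-c4ccccc4)ccc3N)cc2)cnn1C` gives 670 nM, while compound 3 `Nc1ccc(-c2ccccc2)cc1NC(=O)c1ccc(CN2CCC3(CCNC3)CC2)cc1` gives 309 nM as the lowest number of the three. Compound 4 `Nc1ccc(-c2ccccc2)cc1NC(=O)c1ccc(CN2CCC3(CCCN3)CC2)cc1` has the same atoms as compound 3 joined differently (a group of 10 heavy atoms (8 carbon, 2 nitrogen; one five-membered non-aromatic ring with 1 hetero atom, one six-membered non-aromatic ring with 1 hetero atom) in place of a group of 10 heavy atoms (8 carbon, 2 nitrogen; one five-membered non-aromatic ring with 1 hetero atom, one six-membered non-aromatic ring with 1 hetero atom), on a saturated chain carbon bound to an aromatic carbon) on a saturated chain carbon bound to an aromatic carbon. Within the data shown here, two measured steps reach this group, a 12-fold lower number from compound 1 to compound 3 (1.07 log units; beyond the scatter) and a 2.2-fold lower number from compound 2 to compound 3 (0.34 log units; beyond the scatter) but each replaces an unlike group, and no measured pair compares two such arrangements. No step beyond the scatter is therefore expected, and the estimated change is a 1.1-fold higher number from compound 3 to compound 4 (0.05 log units; within the scatter) in no firm direction. For compound 4 the estimate is 350 nM within an expected range of 130 nM to 950 nM in this read-out.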

Compound 4, half-maximal inhibitory concentration: 118 nM
The estimate for compound 4 lay 3.0-fold (0.47 log units) above the measured number; the measured number lies below the stated range.
By their numbers in this assay, from the lowest: compound 4; then compound 3; then compound 2; then compound 1.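

In this assay, joining the same atoms differently at this position gives a 2.6-fold lower number from compound 3 to compound 4 (0.42 log units; beyond the scatter), so the number here depends on how the group is joined, even with its heavy atoms, ring sizes, donors and acceptors counted the same. Compound 4 also has the lowest number of the four, with a 5.7-fold lower number from compound 2 to compound 4 (0.75 log units; beyond the scatter) and a 31-fold lower number from compound 1 to compound 4 (1.49 log units; beyond the scatter). Going by these compounds, whether a piperazine or a morpholine on a saturated chain carbon bound to an aromatic carbon would give a similar number remains open. Nothing shown here explains the difference between the two arrangements.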